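A Methylthiophene Swap on Compound 1

The compounds below may be only part of what the source reports. "The series", "measured", "known", "first", "only" and "open" are said of these compounds alone.

- Compound 1 `CCOc1cc(NC(=O)CCCCC(=O)Nc2cc(-c3ccccc3)ccc2N)cc2c1OCC([N+](=O)[O-])=C2`: 7460 nM
- Compound 2 `CCOc1cc(NC(=O)CCCCCCC(=O)Nc2cc(-c3ccccc3)ccc2N)cc2c1OCC([N+](=O)[O-])=C2`: 5400 nM

Both values were obtained in a functional assay on A549 cells (Homo sapiens) for antiproliferative activity, read by MTT assay, with a stated time of 48 h; on this read-out lower numbers stand for stronger inhibition of growth and higher numbers for weaker inhibition of growth. They lie within the usual scatter of each other, so the numbers do not set compound 1 apart from compound 2. Among the measured compounds shown here, compound 1 therefore stands level with the only other measured compound.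

Compound 3 `CCOc1cc(NC(=O)CCCCC(=O)Nc2cc(-c3ccc(C)s3)ccc2N)cc2c1OCC([N+](=O)[O-])=C2` has not yet been measured in this assay. It shares the core of compound 1 and carries 5-methylthiophen-2-yl in place of phenyl on an aromatic carbon.

For the measured compounds named here, no measured compound shows what a change at this place does, so the data give no firm direction. The expectation rests on compound 1 at 7460 nM and on compound 2 at 5400 nM, and no step beyond the scatter is expected in this assay. The expected change is a 1.4-fold lower number from compound 1 to compound 3 (0.13 log units; within the scatter), a small move towards stronger inhibition of growth that would stay within the scatter. For compound 3 the estimated value is 5500 nM, with an expected range from 2000 nM to 13000 nM.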

Compound 3, concentration for 50% growth inhibition: 13800 nM
For compound 3 the middle estimate is 2.5-fold (0.40 log units) below the measured one, outside the stated range (above it).
By their numbers in this assay, from the lowest: compounds 2, 1 and 3 (each within the scatter of the next, the first and the last beyond it).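

In this assay, the step at this position, with 5-methylthiophen-2-yl in place of phenyl on an aromatic carbon para to an amino group, is a 1.8-fold higher number from compound 1 to compound 3 (0.27 log units; within the scatter). Among the compounds shown here, this is the first reading of any change at this place, as the earlier compounds differed only in their chain. It shows that replacing a six-membered aromatic ring of carbon only with a five-membered aromatic ring holding one sulfur atom and carrying a methyl group leaves the number within the usual scatter, so this exchange gives no clear separation from phenyl, and nothing available accounts for the size of the step.

The compounds shown leave open whether the thiophene ring or its methyl group contributes to this step, which an unsubstituted thiophen-2-yl at the same place would help to separate, and whether a different group here, such as a pyridine or a carboxylic acid on the phenyl ring, would move the number beyond the scatter. They also leave open whether 5-methylthiophen-2-yl would give a similar step on the longer chain of compound 2.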